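This account rests on a few compounds, and the source may have more. Where it says the series, first, only, none or still open, it means among the compounds named here.

Measured so far in an assay on CHO cells for displacement of a labelled ligand from adenosine receptor A1 (Homo sapiens), read by scintillation counting, with a stated time of 3 h; on this read-out lower numbers stand for stronger inhibition and higher numbers for weaker inhibition:
compound 1, `Nc1nc(-c2ccc(CO)cc2)nc2sc(-c3ccccc3)nc12`, gives 82 nM
compound 2, `Nc1nc(-c2ccco2)nc2sc(-c3ccccc3)nc12`, gives 67 nM

For the measured compounds named here, of the two numbers, the number of compound 2 is the lower one, but only just: the single measured step, a 1.2-fold lower number from compound 1 to compound 2 (0.09 log units; within the scatter), lies within the scatter, so the two compounds cannot be told apart on this read-out. Compound 3, `Cc1ccc(-c2nc(N)c3nc(-c4ccccc4)sc3n2)o1`, is the next compound. It differs from compound 2 in one place: methyl in place of hydrogen on an aromatic carbon. Going by the values given here, the one measured step swaps the whole group on the aromatic carbon and says nothing direct about adding a methyl to the furan-2-yl itself; it showed that exchanging that group left the number essentially unchanged. Among the compounds with values here, no measured step bears on a methyl at this position. Within the data shown here, with the only available step within the scatter and no guide for the methyl, the expectation is a step of no more than the scatter in either direction in this assay, written as a 1.1-fold lower number from compound 2 to compound 3 (0.05 log units; within the scatter). Compound 3 is therefore expected to give about 60 nM in this assay, with a range from 25 nM to 150 nM.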

Compound 3, inhibition constant: 28.9 nM
The estimate for compound 3 lay 2.1-fold (0.32 log units) above the measured number; low and high end bracket the measured number.
By their numbers in this assay, from the lowest: compound 3; then compounds 2 and 1 (each within the scatter of the next).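

In this assay, going from furan-2-yl to 5-methylfuran-2-yl gives a 2.3-fold lower number from compound 2 to compound 3 (0.37 log units; beyond the scatter), the first step among these compounds that lies beyond the scatter. A single methyl on this aromatic carbon of the furan ring therefore moves the number, whereas exchanging the whole 4-(hydroxymethyl)phenyl group for furan-2-yl did not, and the 5-methylfuran-2-yl group also stands apart from the 4-(hydroxymethyl)phenyl group, with a 2.8-fold lower number from compound 1 to compound 3 (0.45 log units; beyond the scatter). Nothing available explains why the methyl has this effect on the number.

The compounds shown leave open whether the lower number is particular to methyl or would also follow from an ethyl, a chlorine, a methoxy or a hydroxymethyl on the same carbon, and whether a methyl on either of the other two furan carbons would do the same. They also leave open whether the methyl step would carry over to a core bearing a different group in place of the phenyl, such as a pyridine or a cyclohexyl, and whether it would hold at the other adenosine receptors.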